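A phenylethenyl group replaces dimethoxyphenyl on the shared core

The source may report more compounds than this note shows. Statements on the series, on what has been measured and on what is new or still open speak of the compounds shown alone.

Measured in a functional assay on MGC-803 cells (Homo sapiens) for cytotoxicity, read by MTT assay, with a stated time of 72 h; on this read-out lower numbers stand for stronger inhibition and higher numbers for weaker inhibition:
compound 1 `CN(C)c1ccc(C=C2C(=O)N(c3ccc(Cl)cc3)N(c3ccc(Cl)cc3)C2=O)cc1`: 80200 nM
compound 2 `O=C1C(=Cc2cccc(Cl)c2)C(=O)N(c2ccc(Cl)cc2)N1c1ccc(Cl)cc1`: 14400 nM
compound 3 `COc1ccc(C=C2C(=O)N(c3ccc(Cl)cc3)N(c3ccc(Cl)cc3)C2=O)cc1OC`: > 128000 nM (a limit)

For compound 3 the entry > 128000 nM is a limit of the assay and not a number. The next compound to be tested is compound 4 `O=C1C(=C/C=C/c2ccccc2)C(=O)N(c2ccc(Cl)cc2)N1c1ccc(Cl)cc1`. It differs from compound 3 as follows: 2-phenylethenyl in place of 3,4-dimethoxyphenyl on a double-bonded chain carbon bound to a double-bonded ring carbon. In words, 2-phenylethenyl takes the place of 3,4-dimethoxyphenyl on a double-bonded chain carbon bound to a double-bonded ring carbon.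

Three measured steps at this same place bear on the change. The first, an at least 1.5-fold higher number from compound 1 to compound 3 (0.20 log units; that floor lies within the scatter), has a floor within the scatter. The second, an at least 8.8-fold higher number from compound 2 to compound 3 (0.94 log units; beyond the scatter), is at least modest. The third, a 5.6-fold lower number from compound 1 to compound 2 (0.75 log units; beyond the scatter), is modest. None of them involves 2-phenylethenyl, so they give only a scale for changes at this place.

For compound 4 a lower number than for compound 3 is expected, since compound 1 reads 80200 nM and compound 2 reads 14400 nM with other groups here. The expected size is an at least 3.6-fold lower number from compound 3 to compound 4 (0.56 log units; beyond the scatter) as an estimate only. For compound 4 the estimated value is 35000 nM with an expected range from 9000 nM to 120000 nM in this assay on this reasoning.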

Compound 4, half-maximal inhibitory concentration: 5100 nM
For compound 4 the middle estimate is 6.9-fold (0.84 log units) above the measured one, and the stated range ends above it.
By their numbers in this assay, from the lowest: compound 4; then compound 2; then compound 1. At a limit, above all of these: compound 3.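

In this assay, 2-phenylethenyl gives a 16-fold lower number from compound 1 to compound 4 (1.20 log units; beyond the scatter) and a 2.8-fold lower number from compound 2 to compound 4 (0.45 log units; beyond the scatter), so compound 4, whose group carries a double bond outside aromatic rings, reads lowest of the compounds shown, and this place is not limited to a substituted phenyl ring on the chain carbon. Set against 3,4-dimethoxyphenyl, the same change gives an at least 25-fold lower number from compound 3 to compound 4 (1.39 log units; beyond the scatter), which is a floor and not a full size, and it shows that this place can span a large range of readings on the shared core. Compound 3 itself stands at a limit of the assay and not at a number: the limit of > 128000 nM in this assay, at which 1 of the 4 values shown sits.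

As far as these compounds go, it remains open whether the step belongs to the double bond outside aromatic rings or to the ring of 2-phenylethenyl, as the two enter together in compound 4. Also open, from the compounds shown here alone, is how a longer chain such as 4-phenylbuta-1,3-dienyl, or an amine or a carboxylic acid on the ring of 2-phenylethenyl, would read at this place in this assay.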